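Working notes: amide nitrogen change, compound 2 to compound 4

This account rests on a few compounds, and the source may have more. Where it says the series, first, only, none or still open, it means among the compounds named here.

Measured so far:
- Compound 1 `CCOC(=O)[C@@H]1CCCN(S(=O)(=O)c2ccc(S(=O)(=O)N3CCOCC3)cc2)C1`: in a functional assay on MIA PaCa-2 cells (Homo sapiens) for inhibition, read by MTT assay, with a stated time of 3 days (on this read-out higher numbers stand for weaker inhibition and lower numbers for stronger inhibition), compound 1 sits at the assay limit, > 10000 nM.
- Compound 2 `CCN(CC)S(=O)(=O)c1ccc(S(=O)(=O)N2CCC[C@@H](C(=O)N(C)C(C)C)C2)cc1`: in this assay compound 2 gives only the limit > 10000 nM.
- Compound 3 `CCOC(=O)[C@@H]1C[C@@H](O)CN(S(=O)(=O)c2ccc(S(=O)(=O)N(CC)CC)cc2)C1`: in this assay compound 3 likewise reaches only the limit > 10000 nM.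

Compound 2 therefore stands nowhere in particular on the numbers shown: every value in this assay is a limit rather than a number, and compound 2 is not separable from compound 1 or compound 3 on this basis. Among the compounds with values here, no step between measured compounds is available.

Compound 4 `CCN(CC)S(=O)(=O)c1ccc(S(=O)(=O)N2CCC[C@@H](C(=O)NC)C2)cc1` differs from compound 2 by hydrogen in place of isopropyl on an amide-type nitrogen. With all three measured values sitting at the same limit, there is nothing to suggest the direction of this change, and compound 4 is most plausibly expected to remain at or beyond the limit as well, because of the limit of > 10000 nM in this assay, at which 3 of the 3 values shown sit. The step from compound 2 to compound 4 is therefore estimated as none beyond the scatter, a step that the limit leaves unreadable from compound 2 to compound 4. Compound 4 is expected at 15000 nM, with a range from 5000 nM to 50000 nM, most likely reported only as a limit.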

Compound 4, half-maximal inhibitory concentration: > 10000 nM
Compound 4: a limit, no number; the forecaster's own chance of this, stated with the estimate: 80%; the middle value does not contradict the limit.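

In this assay compound 2 and compound 4 each give only a limit, and no step can be read between them for hydrogen in place of isopropyl on the amide-type nitrogen. The compounds shown leave open which structural change, if any, would yield a number rather than a limit.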